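This account rests on a few compounds, and the source may have more. Where it says the series, first, only, none or still open, it means among the compounds named here.

Measured so far:
compound 1 `COc1ccc(SCc2ccc(/C=C/C(=O)Nc3ccccc3N)cc2)cc1OC`: 14.3%
compound 2 `Nc1ccccc1NC(=O)c1ccc(CSc2nccc(C(F)(F)F)n2)cc1`: 66.1%

In a functional assay on SMMC-7721 cells (Homo sapiens) for inhibition, read by CCK-8 assay, with a stated time of 72 h, tested at 2 uM (on this read-out higher numbers stand for more inhibition of growth at the one concentration tested and lower numbers for less inhibition of growth), compound 1 gives 14.3%, the lower of the two numbers; compound 2 gives 66.1%, which lies beyond the usual scatter above it. Among the compounds with values here, these two differ in several places, so no single step between them can be read. Compound 3 `Nc1ccccc1NC(=O)/C=C/c1ccc(CSc2ccc(C(F)(F)F)cn2)cc1` is not yet measured; it arises from compound 1 by the change (5-(trifluoromethyl)pyridin-2-yl in place of 3,4-dimethoxyphenyl on a sulfur). Because compound 2 gives 66.1% while carrying a similar group, an upward step beyond the scatter is expected, a number 25.7 percentage points higher from compound 1 to compound 3 (beyond the scatter). Compound 3 is estimated to reach 40%, between 20% and 65%.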

Compound 3, percent growth inhibition at one concentration: 12.1%
Estimate against measurement, compound 3: 27.9 percentage points above; measured number outside the range, below it.
By their numbers in this assay, from the lowest: compounds 3 and 1 (each within the scatter of the next); then compound 2.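

In this assay, placing 5-(trifluoromethyl)pyridin-2-yl in place of 3,4-dimethoxyphenyl on a sulfur gives a number 2.2 percentage points lower from compound 1 to compound 3 (within the scatter), so this exchange of one aromatic ring for another does not separate the two compounds. On the core of compound 1, this change at the sulfur leaves no readable shift at the one concentration tested. Nothing measured here bears on this result. Compound 2 differs from both in several places, so its steps cannot be read. Open, from the compounds shown here alone, is whether a saturated chain ending in an amine or a carboxylic acid on that sulfur would move the number.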